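The compounds below may be only part of what the source reports. "The series", "measured", "known", "first", "only" and "open" are said of these compounds alone.

In a functional assay on MDA-MB-436 cells (Homo sapiens) for antiproliferative activity, read by MTT assay, with a stated time of 48 h (a lower number here means a stronger inhibitor, a higher number a weaker inhibitor), compound 1 `C=CS(=O)(=O)N1CCN(c2ccn3ncc(-c4ccccc4)c3n2)CC1` gives 19500 nM, compound 2 `C=CS(=O)(=O)N1CCN(c2ncnc3ccc(-c4ccccc4)cc23)CC1` gives 23400 nM, and compound 3 `C=CS(=O)(=O)N1CCN(c2ncnc3sc(-c4ccc(C#N)cc4)cc23)CC1` gives 9170 nM. Compound 3 holds the lowest of these three numbers, and its gap to each of the other two lies beyond the scatter. Compound 4 `C=CS(=O)(=O)N1CCN(c2ncnc3sc(-c4cn(C)nc4C(F)(F)F)cc23)CC1` differs from compound 3 in one place: 1-methyl-3-(trifluoromethyl)-1H-pyrazol-4-yl in place of 4-cyanophenyl on an aromatic carbon. It has 1-methyl-3-(trifluoromethyl)-1H-pyrazol-4-yl in place of 4-cyanophenyl on an aromatic carbon. Within the data shown here, no measured pair differs in one place only, so the series offers no direct precedent for this change. In this assay the expected result is no step beyond the scatter, with the estimated step of a 1.3-fold higher number from compound 3 to compound 4 (0.12 log units; within the scatter). The estimate for compound 4 is 12000 nM, with an expected range of 4000 nM to 35000 nM.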

Compound 4, half-maximal inhibitory concentration: 15100 nM
Beside the measured number, compound 4's estimate is 1.3-fold (0.10 log units) below it; the measured number falls inside the stated range.
By their numbers in this assay, from the lowest: compounds 3, 4, 1 and 2 (each within the scatter of the next, the first and the last beyond it).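

In this assay, among these compounds, the first one-place comparison gives a 1.6-fold higher number from compound 3 to compound 4 (0.22 log units; within the scatter). On this aromatic carbon next to the ring sulfur, 1-methyl-3-(trifluoromethyl)-1H-pyrazol-4-yl thus replaces 4-cyanophenyl without a step beyond the scatter, so for this pair neither the six-membered ring nor the nitrile is needed to hold the number. No measured property bears on this result. As far as these compounds go, whether a primary amine or a carboxylic acid in place of the nitrile would give a step beyond the scatter stays open. Also open, from the compounds shown here alone, is whether the pyrazole exchange carries over to the cores of compound 1 and compound 2.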